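Swapping Methyl for Tert-Butyl

The source may report more compounds than this note shows. Statements on the series, on what has been measured and on what is new or still open speak of the compounds shown alone.

In a functional assay on the whole organism for inhibition, with Rattus norvegicus as the target (a lower number here means that less compound is needed, a higher number that more compound is needed for the effect), compound 3 (`Cc1ccc(OC(Cc2ccc(Cl)cc2)C(=O)O)cc1`) gives > 25 mg/kg as a limit and not a number. Compound 1 (`CC(C)c1ccc(OC(Cc2ccc(C(F)(F)F)cc2)C(=O)O)cc1`) gives 10 mg/kg as a true number. Compound 2 (`COc1ccc(CC(Oc2ccc(C(C)C)cc2)C(=O)O)cc1`) gives > 50 mg/kg as another limit. Compound 4 (`CC(C)(C)c1ccc(OC(Cc2ccc(Cl)cc2)C(=O)O)cc1`) differs from compound 3 by tert-butyl in place of methyl on an aromatic carbon. Going by the values given here, the only measured step is an at least 5.0-fold higher number from compound 1 to compound 2 (0.69 log units; beyond the scatter) and it concerns methoxy in place of trifluoromethyl, so it bears on this swap only loosely. Compound 1 at 10 mg/kg shows that a real number is reachable with this core. Expected, with much uncertainty, is an at least 1.6-fold lower number from compound 3 to compound 4 (0.22 log units; that floor lies within the scatter) with less compound needed. For compound 4 the estimated value is 15 mg/kg with a range from 6 mg/kg to 40 mg/kg around it.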

Compound 4, dose for half-maximal effect: 25 mg/kg
Estimate against measurement, compound 4: 1.7-fold (0.22 log units) below; low and high end bracket the measured number.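

Replacing methyl with tert-butyl, on an aromatic carbon para to a large group, gives a number no higher from compound 3 to compound 4 (the limit leaves the size open). The larger group is tolerated here, and in this assay compound 4 gives a true number, 25 mg/kg. The size of the change cannot be read because compound 3 has only a limit and not a number: the limit of > 25 mg/kg in this assay, at which 1 of the 4 values shown sits.

The compounds shown leave open how an amine or a longer alkyl chain would behave at this position. Also open, as far as these compounds go, is how isopropyl would read there with the chlorine of compound 4 kept in place.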